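A few compounds are considered here, and "the series" means these few. Any claim that something is new, unique, unknown or untested is made for them only; others in the source may bear on it.

Measured compounds:
compound 1 `CS(=O)(=O)c1ccc(-c2cnc3[nH]cc(-c4nnc(-c5ccccc5)o4)c(=O)c3c2)cc1` – 5.46%
compound 2 `N#Cc1ccc(-c2cnc3[nH]cc(-c4nnc(-c5ccc(Cl)cc5)o4)c(=O)c3c2)cc1` – 11.5%

Both numbers come from a functional assay on HepG2 cells (Homo sapiens) for inhibition, read by MTT assay, with a stated time of 24 h, tested at 5 uM; on this read-out higher numbers stand for more inhibition of growth at the one concentration tested and lower numbers for less inhibition of growth. Compound 1 gives 5.46%, the lower of the two numbers shown; compound 2 gives 11.5%, a number that lies within the scatter of the measurement of compound 1, so the two cannot be told apart. Within the data shown here, compound 2 differs from compound 1 in more than one place, and no single step between them is available.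

Compound 3 `Cc1cccc(-c2nnc(-c3c[nH]c4ncc(-c5ccc(S(C)(=O)=O)cc5)cc4c3=O)o2)c1` is not yet measured. It differs from compound 1 by methyl in place of hydrogen on an aromatic carbon; read one bond further out, the change is phenyl to 3-methylphenyl. Among the measured compounds shown here, nothing among the measured compounds shows what such a methyl does on this core, so no step beyond the scatter is expected in either direction in this assay. The step of a number 2.5 percentage points higher from compound 1 to compound 3 (within the scatter) is expected to stay within the scatter. For compound 3 the expected value is 8%, with a range from 0% to 20%.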

Compound 3, percent growth inhibition at one concentration: 13.2%
Compound 3: middle estimate off by 5.2 percentage points, on the low side; the measured number falls inside the stated range.
By their numbers in this assay, from the lowest: compounds 1, 2 and 3 (each within the scatter of the next).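

In this assay, among these compounds, phenyl to 3-methylphenyl is the first single change that can be read on the shared core, giving a number 7.7 percentage points higher from compound 1 to compound 3 (within the scatter) for methyl in place of hydrogen. A methyl on this aromatic carbon, meta to a large group, therefore produces no step beyond the scatter, though one such step at a single concentration cannot show whether a small effect lies underneath. Nothing available bears on why this position gives this reading.

Going by these compounds, whether an amine, a carboxylic acid or a longer chain at this same carbon would move the number beyond the scatter remains open, as does the effect of methyl elsewhere on this ring. Compound 2 has no single-change link to compound 1 or compound 3, so the steps to it cannot be read.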